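Trifluoromethyl ketones: removing the ring octyl

This account rests on a few compounds, and the source may have more. Where it says the series, first, only, none or still open, it means among the compounds named here.

Among the measured compounds shown here, compound 1 `CCCCCCCCCC(=O)C(F)(F)F` and compound 2 `CCCCCCCCc1ccccc1CCCCCCCC(=O)C(F)(F)F` are the two measured members. In an assay on liver for inhibition of Fatty-acid amide hydrolase 1 (Rattus norvegicus) (on this read-out higher numbers stand for weaker inhibition and lower numbers for stronger inhibition), compound 1 gives 130 nM, and compound 2 gives 320 nM, the higher of the two numbers, a gap that lies beyond the scatter. Compound 3 `O=C(CCCCCCCc1ccccc1)C(F)(F)F` differs from compound 2 by hydrogen in place of octyl on an aromatic carbon. The numbers of compound 1 and compound 2 give no direct guide to this change, so a modest rise in the number is expected, close to the edge of the scatter. On that basis compound 3 is estimated at 500 nM in this assay, within 150 nM to 2000 nM, which means an expected step of a 1.6-fold higher number from compound 2 to compound 3 (0.19 log units; within the scatter).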

Compound 3, inhibition constant: 25 nM
Compound 3: middle estimate off by 20-fold (1.30 log units), on the high side; the whole stated range lies above it.
By their numbers in this assay, from the lowest: compound 3; then compound 1; then compound 2.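

In this assay, hydrogen in place of octyl on the aromatic carbon gives a 13-fold lower number from compound 2 to compound 3 (1.11 log units; beyond the scatter), so at this position the octyl goes with a much higher number, which the first two compounds could not show. Phenyl in place of ethyl on a saturated chain carbon gives a 5.2-fold lower number from compound 1 to compound 3 (0.72 log units; beyond the scatter), so the aromatic ring without octyl goes with a lower number than the plain chain. No evidence at hand bears on the reason for either step. Open, going by these compounds, is how a methyl or a methoxy group on that aromatic carbon would fall between hydrogen and octyl. Also open, on these data alone, is whether a longer chain between the aromatic ring and the carbonyl would move the number of compound 3.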